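Amide substituent series on the shared core: step to compound 4

This account rests on a few compounds, and the source may have more. Where it says the series, first, only, none or still open, it means among the compounds named here.

Three compounds share one core and differ only in the amide group on a carbonyl carbon. Compound 1 `Cc1ccc(CN(C)C(=O)c2nn(-c3ccc(F)cc3)c(OC[C@@H](O)C[C@@H](O)CC(=O)O)c2C(C)C)cc1` carries methyl(4-methylbenzyl)amino and in a functional assay on L6 cells (Rattus norvegicus) for inhibition (a higher number here means a weaker inhibitor, a lower number a stronger inhibitor), compound 1 gives 1250 nM. Compound 2 `COc1ccc(CNC(=O)c2nn(-c3ccc(F)cc3)c(OC[C@@H](O)C[C@@H](O)CC(=O)O)c2C(C)C)cc1` carries (4-methoxybenzyl)amino; in this assay compound 2 gives "not determined" (no result reported). Among the compounds with values here, compound 3 `COc1cccc(CNC(=O)c2nn(-c3ccc(F)cc3)c(OC[C@@H](O)C[C@@H](O)CC(=O)O)c2C(C)C)c1` carries (3-methoxybenzyl)amino and in this assay compound 3 gives 8750 nM, the highest of the two numbers in hand; the only step to it, a 7.0-fold higher number from compound 1 to compound 3 (0.85 log units; beyond the scatter), is beyond the scatter.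

Compound 4 `CC(C)c1c(C(=O)N(C)Cc2ccc(F)cc2)nn(-c2ccc(F)cc2)c1OC[C@@H](O)C[C@@H](O)CC(=O)O` is the next entry. The change from compound 3 reads ((4-fluorobenzyl)(methyl)amino in place of (3-methoxybenzyl)amino on a carbonyl carbon). Within the data shown here, the entering group, like the methyl(4-methylbenzyl)amino of compound 1, has no hydrogen-bond donor and carries a methyl on the amide, so the only step that bears on it is a 7.0-fold higher number from compound 1 to compound 3 (0.85 log units; beyond the scatter), read in reverse. Among the measured compounds shown here, a return toward the number of compound 1 is therefore expected, as a drop beyond the scatter, though the fluorine in place of the methyl on the benzyl ring has no measured counterpart here.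

For compound 4 the expected value in this assay is 1600 nM, within 600 nM to 4500 nM, which means an expected step of a 5.5-fold lower number from compound 3 to compound 4 (0.74 log units; beyond the scatter).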

Compound 4, half-maximal inhibitory concentration: 2800 nM
The estimate for compound 4 lay 1.8-fold (0.24 log units) below the measured number; measured number inside the range.
By their numbers in this assay, from the lowest: compound 1; then compound 4; then compound 3.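

In this assay, (4-fluorobenzyl)(methyl)amino in place of (3-methoxybenzyl)amino on the carbonyl carbon gives a 3.1-fold lower number from compound 3 to compound 4 (0.49 log units; beyond the scatter), so compound 4 joins compound 1 as a second amide without the amide hydrogen that gives a lower number than compound 3, although this change also alters the ring substituent. The pair of compound 1 and compound 4 is more specific, as it keeps the methyl on the amide and changes only the substituent on the benzyl ring: fluoro in place of methyl gives a 2.2-fold higher number from compound 1 to compound 4 (0.35 log units; beyond the scatter), showing that this ring substituent alone shifts the number beyond the scatter. No supporting measurement bears on the reason for either step.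

Within the data shown here, no pair of compounds here differs only in the methyl on the amide. Compound 2 has no number, and steps involving it cannot be read. Also open, going by these compounds, is how a chloro or trifluoromethyl group on the benzyl ring, or a phenethyl group in place of the benzyl, would read in this assay.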